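Swapping One Dichlorophenyl Isomer for Another

The source may report more compounds than this note shows. Statements on the series, on what has been measured and on what is new or still open speak of the compounds shown alone.

In a functional assay on MDA-MB-231 cells (Homo sapiens) for antiproliferative activity, read by MTT assay, with a stated time of 48 h (on this read-out higher numbers stand for weaker inhibition and lower numbers for stronger inhibition), compound 1 `C#Cc1cccc(Nc2ncnc3cc(NC(=O)/C=C/c4ccccc4)sc23)c1` gives 2340 nM and compound 2 `O=C(/C=C/c1ccccc1)Nc1cc2c(Nc3ccc(Cl)c(Cl)c3)ncnc2s1` gives 4400 nM. For the measured compounds named here, compound 2 thus stands within the usual scatter of compound 1, the only other number available. Compound 3 `O=C(/C=C/c1ccccc1)Nc1cc2c(Nc3cc(Cl)cc(Cl)c3)ncnc2s1` carries 3,5-dichlorophenyl in place of 3,4-dichlorophenyl on a nitrogen on an aromatic ring. Going by the values given here, no measured pair shows a change of this kind, so in this assay the expected outcome is a 1.0-fold higher number from compound 2 to compound 3 (0.01 log units; within the scatter), with no shift beyond the scatter. The estimated value for compound 3 is 4500 nM, with an expected range from 1800 nM to 11000 nM.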

Compound 3, half-maximal inhibitory concentration: 11500 nM
The estimate for compound 3 lay 2.6-fold (0.41 log units) below the measured number; measured number outside the range, above it.
By their numbers in this assay, from the lowest: compounds 1 and 2 (each within the scatter of the next); then compound 3.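

In this assay, for the compounds shown here, 3,5-dichlorophenyl in place of 3,4-dichlorophenyl on a nitrogen on an aromatic ring gives a 2.6-fold higher number from compound 2 to compound 3 (0.42 log units; beyond the scatter) and is the first step that can be read at this position. The two groups have the same atoms and the same counts, so the arrangement of the two chlorines alone separates compound 2 from compound 3 here. Nothing at hand accounts for this step. Going by these compounds, whether a similar step would appear with 3,4-difluorophenyl and 3,5-difluorophenyl remains open. So does where a single chlorine, as in 3-chlorophenyl or 4-chlorophenyl, would fall.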